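Methoxy to Trifluoromethylsulfanyl: Cytotoxicity Expected to Stay Undetectable

A few compounds are considered here, and "the series" means these few. Any claim that something is new, unique, unknown or untested is made for them only; others in the source may bear on it.

Compound 1, `COc1ccc(NC(=O)Nc2cc(C)nc3ccccc23)cc1`, was tested in an ADME assay on HepG2 cells (Homo sapiens) for cytotoxicity, with a stated time of 72 h; a higher number here means that more compound is needed for the effect, a lower number that less compound is needed. In this assay compound 1 returns only a limit, > 25000 nM. Its two close relatives sit at the same limit. Compound 2, `COc1ccc(NC(=O)Nc2cc(C)nc3ccccc23)cc1F`, gives a limit of > 25000 nM in this assay. Compound 3, `COc1ccc(NC(=O)Nc2cc(C)nc3ccccc23)cc1Cl`, likewise gives a limit of > 25000 nM in this assay. The step that the two limits leave unreadable from compound 1 to compound 2, the step that the two limits leave unreadable from compound 1 to compound 3 and the step that the two limits leave unreadable from compound 2 to compound 3 therefore carry no readable size; all that can be said is that (the limit of > 25000 nM in this assay, at which 3 of the 3 values shown sit).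

Compound 4, `Cc1cc(NC(=O)Nc2ccc(SC(F)(F)F)cc2)c2ccccc2n1`, is not yet measured. It differs from compound 1 in one place: (trifluoromethyl)sulfanyl in place of methoxy on an aromatic carbon. Going by the values given here, none of the measured steps touches this position, and each of them was unreadable, so they give no direction for the new step. The expectation is that compound 4 stays where compound 1 stands. The step of a number no higher from compound 1 to compound 4 (the limit leaves the size open) is therefore expected to be no larger than the scatter. Compound 4 is estimated at 25000 nM in this assay, within a range from 8000 nM to 60000 nM, with the most likely outcome once more a limit rather than a number.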

Compound 4, half-maximal effective concentration: 20000 nM
Estimate against measurement, compound 4: 1.3-fold (0.10 log units) above; low and high end bracket the measured number.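

Going by these compounds alone, with (trifluoromethyl)sulfanyl in place of methoxy, this position yields the first actual number: in this assay compound 4 gives 20000 nM. The earlier compounds shown here returned only a limit. The change is recorded as an at least 1.2-fold lower number from compound 1 to compound 4 (0.09 log units; that floor lies within the scatter), so the data fix a floor for this step and not its size, and that floor does not by itself establish a real drop. Compound 4 is therefore the only compound shown that returns a number in this assay, while the others stay at a shared limit: the limit of > 25000 nM in this assay, at which 3 of the 4 values shown sit.

The compounds shown leave open whether a number in this assay is particular to (trifluoromethyl)sulfanyl, or whether another replacement for methoxy at this place, such as an amine, a carboxylic acid or a longer chain, would also give one. Within the data shown here, they also leave open how the fluoro and chloro changes seen in compound 2 and compound 3 would read when combined with (trifluoromethyl)sulfanyl, since those changes have so far been seen only with methoxy and only as limits.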